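Trimming the Allyl Group: Expected Binding of Compound 4

This account rests on a few compounds, and the source may have more. Where it says the series, first, only, none or still open, it means among the compounds named here.

Measured compounds:
compound 1 `C=CCc1cc(C(C)=O)c(O)cc1OCCCCC`: 23%
compound 2 `C=CCCCCOc1cc(O)c(C(C)=O)cc1CC=C`: 27%
compound 3 `C=CCc1cc(C(C)=O)c(O)cc1OCc1cccc(C#N)c1`: 58%

In an assay on isolated protein for binding affinity to leukotriene B4 receptor 1 (Homo sapiens), tested at 1 uM (a lower number here means less inhibition, a higher number more inhibition at the concentration tested (going by the name of the read-out)), compound 3 stands highest, with 58%, while compound 2 gives 27% and compound 1 gives 23%. How the core of compound 3 differs from that of compound 2 is not broken down here. Compound 4 `CCc1cc(C(C)=O)c(O)cc1OCc1cccc(C#N)c1` arises from compound 3 by methyl in place of vinyl on a saturated chain carbon bound to an aromatic carbon. The same kind of change, (methyl in place of vinyl on a saturated chain carbon, four bonds along the chain from an oxygen on an aromatic ring), is already measured once, giving a number 4 percentage points lower from compound 2 to compound 1 (within the scatter); the place differs, the earlier change sitting four bonds along the chain from an oxygen on an aromatic ring, the new one on a saturated chain carbon bound to an aromatic carbon. Resting on compound 3 with 58% and on the small earlier step, compound 4 is expected to give 53%, a step of a number 5 percentage points lower from compound 3 to compound 4 (within the scatter), within the scatter.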

Compound 4, a percentage reported as inhibition, at one concentration (the size of the read-out at that concentration, not a potency): 61%
Compound 4: the middle estimate sits 8 percentage points below what was measured, within the range that was stated.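

In this assay, the change of allyl to ethyl gives a number 3 percentage points higher from compound 3 to compound 4 (within the scatter). Set beside the earlier case, the same kind of change behaves alike on the two cores, with no difference that can be told apart: the same change on two cores in this assay, a number 4 percentage points lower (within the scatter) from compound 2 to compound 1 and a number 3 percentage points higher (within the scatter) from compound 3 to compound 4, 7 percentage points apart, within the scatter of two such steps This shows only that, on these two cores and at these two places, the change leaves the number within the scatter; it does not show that the same would hold on other cores in the series.

The compounds shown leave open whether a longer chain or an amine in place of the allyl group would move the number beyond the scatter. From the compounds shown here alone, it also remains open whether a carboxylic acid in place of the nitrile would alter the result of this change.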